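The source may hold more compounds than are shown below. What is called first, only, known or untested is meant among the compounds shown, and "the series" means these compounds.

Compound 1 `CC(C)[C@@H]1CC[C@@H](C)C[C@@]12N(C)C(=O)[C@@H]1[C@H]3C(=O)NC(=O)[C@H]3ON12` and compound 2 `CC(C)[C@@H]1CC[C@@H](C)C[C@@]12N(C)C(=O)[C@@H]1[C@H]3C(=O)N(c4ccc(Cl)cc4)C(=O)[C@H]3ON12` share one core and differ only on an amide-type nitrogen in a ring. In a functional assay, read by spectrophotometry, with a stated time of 2 h, tested at 3 mg/mL (on this read-out lower numbers stand for a weaker effect and higher numbers for a stronger effect at the one concentration tested), compound 1 gives 47.3%, while compound 2 gives 73.3%, the higher of the two numbers; the change of 4-chlorophenyl in place of hydrogen on that nitrogen is a number 26 percentage points higher from compound 1 to compound 2 (beyond the scatter). Compound 3 `CC(C)[C@@H]1CC[C@@H](C)C[C@@]12N(C)C(=O)[C@@H]1[C@H]3C(=O)N(c4ccc5ccccc5c4)C(=O)[C@H]3ON12` is not yet measured in this assay. It differs from compound 2 in one place: naphthalen-2-yl in place of 4-chlorophenyl on an amide-type nitrogen in a ring. For the measured compounds named here, the single measured step concerns the arrival of an aromatic group on that nitrogen, not an exchange of one aromatic group for another, so it bears on this step only loosely. Compound 3 is therefore expected to stay near compound 2, with a step of a number 1.7 percentage points higher from compound 2 to compound 3 (within the scatter) that need not exceed the scatter. Compound 3 is estimated at 75%, within a range from 55% to 90%.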

Compound 3, a percentage reported as activity, at one concentration (the size of the read-out at that concentration, not a potency): 57.4%
The estimate for compound 3 lay 17.6 percentage points above the measured number; the measured number falls inside the stated range.
By their numbers in this assay, from the lowest: compound 1; then compound 3; then compound 2.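

Exchanging one aromatic group for another on the amide-type nitrogen is not a neutral change: in this assay, naphthalen-2-yl in place of 4-chlorophenyl gives a number 15.9 percentage points lower from compound 2 to compound 3 (beyond the scatter) and so the number depends on which aromatic group sits there, not only on whether one is present. Naphthalen-2-yl in place of hydrogen still gives a number 10.1 percentage points higher from compound 1 to compound 3 (beyond the scatter) and thus both aromatic groups shown stand above the amide hydrogen, by different amounts. No measurement at hand accounts for the gap between the two aromatic groups.

The step from compound 2 to compound 3 removes the chlorine and adds a second aromatic ring together, so the compounds shown do not separate these two changes. Also open, from the compounds shown here alone, is how a plain phenyl, a benzyl or a longer alkyl chain would behave on that nitrogen.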